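Moving One Fluorine: From 2-Fluorophenyl to 4-Fluorophenyl

The compounds below may be only part of what the source reports. "The series", "measured", "known", "first", "only" and "open" are said of these compounds alone.

- Compound 1 `CCS(=O)(=O)c1ccc(CN(CC(C)C)S(=O)(=O)c2ccc3c(c2)C(O)CC(C2CCOCC2)O3)nc1`: 1.42
- Compound 2 `CC(C)CN(c1ccccc1F)S(=O)(=O)c1ccc2c(c1)C(O)CC(C1CCOCC1)O2`: 3.39

Within the data shown here, in a physicochemical assay for lipophilicity, at pH 7.4 (on this read-out lower numbers stand for lower lipophilicity and higher numbers for higher lipophilicity), compound 2 stands highest of the two measured so far, at 3.39, and compound 1 gives 1.42. The gap between the two lies beyond the scatter. Compound 3 `CC(C)CN(c1ccc(F)cc1)S(=O)(=O)c1ccc2c(c1)C(O)CC(C1CCOCC1)O2` has the same atoms as compound 2, joined differently: 4-fluorophenyl in place of 2-fluorophenyl on a sulfonamide nitrogen. In words, 4-fluorophenyl takes the place of 2-fluorophenyl on a sulfonamide nitrogen. Among the measured compounds shown here, only one measured step bears on this, and it is large: a number 1.97 log units higher from compound 1 to compound 2 (beyond the scatter). That step exchanges a whole group, (5-(ethylsulfonyl)pyridin-2-yl)methyl, so it offers only a distant guide. For the measured compounds named here, no measured pair shows what moving the fluorine does. In this assay no step beyond the scatter is therefore expected. The expected step is a number 0.11 log units higher from compound 2 to compound 3 (within the scatter). For compound 3 the estimated value is 3.5, with an expected range from 3.1 to 3.9.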

Compound 3, distribution coefficient: 3.39
The estimate for compound 3 lay 0.11 log units above the measured number; the range from low to high includes it.
By their numbers in this assay, from the lowest: compound 1; then compounds 2 and 3 (each within the scatter of the next).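

In this assay, putting 4-fluorophenyl in place of 2-fluorophenyl on a sulfonamide nitrogen gives no change at the digits printed from compound 2 to compound 3 (within the scatter), so for this pair the place of the fluorine on the ring does not show on this read-out. The large exchange of a whole group is now seen with a second fluorophenyl: 4-fluorophenyl in place of (5-(ethylsulfonyl)pyridin-2-yl)methyl gives a number 1.97 log units higher from compound 1 to compound 3 (beyond the scatter), so here the choice of group matters far more than the place of the fluorine. No separate measurement bears on what lies behind this result.

Still open, as far as these compounds go, is how a phenyl ring carrying a methoxy group or a nitrile instead of fluorine would read in this assay. A plain phenyl group at this sulfonamide nitrogen would show whether the fluorine itself makes any difference.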